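Methoxy removal on a pyrazolyl-chalcone series at one concentration

This account rests on a few compounds, and the source may have more. Where it says the series, first, only, none or still open, it means among the compounds named here.

Measured compounds:
compound 1, `COc1ccc(-c2cc(/C=C/C(=O)c3ccc(N)cc3)[nH]n2)cc1`, 97%
compound 2, `COc1ccc(-c2cc(/C=C/C(=O)c3ccc(N)cc3)[nH]n2)cc1OC`, 92%
compound 3, `COc1cc(C(=O)/C=C/c2cc(-c3cc(OC)c(OC)c(OC)c3)n[nH]2)cc(OC)c1OC`, 103%

Of the compounds shown here, three have been tested in a functional assay on COLO 205 cells (Homo sapiens) for cytotoxicity, read by sulforhodamine B assay, with a stated time of 48 h, tested at 0.01 uM; on this read-out higher numbers stand for a weaker effect at the one concentration tested and lower numbers for a stronger effect. Compound 1 gives 97%, compound 2 gives 92%, and compound 3 gives 103%. The difference between compound 2 and compound 3 as cores is not broken down here. From compound 2 to compound 1 one change is made, (hydrogen in place of methoxy on an aromatic carbon), and the step it brings is a number 5 percentage points higher from compound 2 to compound 1 (within the scatter).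

Compound 4, `COc1ccc(-c2cc(/C=C/C(=O)c3cc(OC)c(OC)c(OC)c3)[nH]n2)cc1OC`, has not yet been measured in this assay. It differs from compound 3 by hydrogen in place of methoxy on an aromatic carbon. Going by the values given here, this is the same kind of change as the one from compound 2 to compound 1, though not the same: in compound 3 the place is also meta to a methoxy group, whereas in compound 2 it is not.

Because the earlier step is a number 5 percentage points higher from compound 2 to compound 1 (within the scatter), compound 4 is expected to show a step of about a number 3 percentage points lower from compound 3 to compound 4 (within the scatter) in this assay. The estimate for compound 4 is 100%, expected to fall between 88% and 110%.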

Compound 4, a percentage reported as activity, at one concentration (the size of the read-out at that concentration, not a potency): 99%
Estimate against measurement, compound 4: 1 percentage points above; the measured number falls inside the stated range.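

In this assay, putting hydrogen in place of methoxy on an aromatic carbon gives a step of a number 4 percentage points lower from compound 3 to compound 4 (within the scatter). Set beside the earlier step, the change shows no difference between the two cores that can be told apart: the same change on two cores in this assay, a number 5 percentage points higher (within the scatter) from compound 2 to compound 1 and a number 4 percentage points lower (within the scatter) from compound 3 to compound 4, 9 percentage points apart, within the scatter of two such steps. This does not show that the change acts alike on both cores, since each step lies within the scatter and so gives the change no direction of its own, and a reading at a single concentration is not a potency.

The compounds shown vary only in methoxy groups and hydrogen on the aromatic rings, with an amine on the ketone-side ring of compound 1 and compound 2. From the compounds shown here alone, what a hydroxyl group, a fluorine atom or a carboxylic acid would do in place of the methoxy group on either core stays open.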